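The source may report more compounds than this note shows. Statements on the series, on what has been measured and on what is new or still open speak of the compounds shown alone.

In a functional assay on PC-3 cells (Homo sapiens) for cytotoxicity, read by WST assay, with a stated time of 72 h (on this read-out lower numbers stand for stronger inhibition and higher numbers for weaker inhibition), compound 1 (`O=C1Nc2c(ccc(F)c2F)C1(c1ccc(O)cc1)c1ccc(F)cc1`) gives 8.6 nM while compound 2 (`O=C1Nc2c(ccc(F)c2F)C1(c1ccncc1)c1ccc(O)cc1`) gives 110 nM as the higher of the two numbers. Compound 3 (`CCCC1(c2ccc(O)cc2)C(=O)Nc2c1ccc(F)c2F`) carries propyl in place of pyridin-4-yl on a saturated ring carbon. Within the data shown here, the only measured step at this carbon is the large 13-fold higher number from compound 1 to compound 2 (1.11 log units; beyond the scatter) that came with pyridin-4-yl, so removing that group may recover part of the step, although no measured compound has propyl there. A lower number is expected, with an estimated 3.7-fold lower number from compound 2 to compound 3 (0.56 log units; beyond the scatter) in this assay overall. For compound 3 the expected value of 30 nM has an estimated range of 6 nM to 150 nM around it.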

Compound 3, half-maximal inhibitory concentration: > 1000 nM
Compound 3 gave a limit, no number (the forecaster's own chance of this, stated with the estimate: 2%); middle value at least 33-fold (1.52 log units) from the limit.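

In this assay, replacing the ring at this saturated ring carbon with a chain does not recover potency: propyl gives an at least 9.0-fold higher number from compound 2 to compound 3 (0.95 log units; beyond the scatter), and an at least 110-fold higher number from compound 1 to compound 3 (2.06 log units; beyond the scatter). Pyridin-4-yl, which had looked like a costly change, therefore retains far more activity than propyl does. Compound 3 gives only a limit of the assay, not a number: the limit of > 1000 nM in this assay, at which 1 of the 3 values shown sits. The compounds shown leave open whether a saturated ring such as cyclohexyl would keep activity at this carbon, or whether an aromatic ring is needed. From the compounds shown here alone, how a longer chain or an amine there would read also stays open.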